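The compounds below may be only part of what the source reports. "The series", "measured", "known", "first", "only" and "open" are said of these compounds alone.

Compound 3 `COc1ccc(Cl)cc1C(=O)Nc1ccc(C2=NN(c3ccccc3)C(c3ccccc3[N+](=O)[O-])C2)cc1` gives 80.2% in a functional assay on the whole organism (strain albino) with Rattus norvegicus as the target, read by paw edema, with stated times of 1 h and 4 h, at a dose of 25 mg/kg by the oral route (a lower number here means a weaker effect, a higher number a stronger effect of the compound at the dose given), the lowest of the three numbers measured. Compound 2 `COc1ccc(C2CC(c3ccc(NC(=O)c4cc(Cl)ccc4OC)cc3)=NN2c2ccccc2)cc1` gives 94.8% in this assay, and compound 1 `COc1ccc(Cl)cc1C(=O)Nc1ccc(C2=NN(C)C(c3ccc([N+](=O)[O-])cc3)C2)cc1` gives 93%; those two values lie within the scatter of each other. Among the measured compounds shown here, the one measured step that touches the same place is a number 14.6 percentage points lower from compound 2 to compound 3 (beyond the scatter), where the 4-methoxyphenyl group on the saturated ring carbon gave way to 2-nitrophenyl. Compound 4 `COc1ccc(Cl)cc1C(=O)Nc1ccc(C2=NN(c3ccccc3)C(c3ccc([N+](=O)[O-])cc3)C2)cc1` is not yet measured. It differs from compound 3 as 4-nitrophenyl in place of 2-nitrophenyl on a saturated ring carbon. For the measured compounds named here, no measured step swaps one nitrophenyl for the other directly, but compound 1 carries the same 4-nitrophenyl group on that carbon and reaches 93%, and the drop seen in a number 14.6 percentage points lower from compound 2 to compound 3 (beyond the scatter) arrived with the 2-nitrophenyl group that now leaves. A modest rise in this assay is therefore expected, with a number 9.8 percentage points higher from compound 3 to compound 4 (within the scatter) as the estimated step. Compound 4 is estimated at 90%, in a range from 80% to 97%.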

Compound 4, a percentage reported as activity, at one dose (the size of the read-out at that dose, not a potency): 90.9%
Estimate against measurement, compound 4: 0.9 percentage points below; the measured number falls inside the stated range.
By their numbers in this assay, from the lowest: compound 3; then compounds 4, 1 and 2 (each within the scatter of the next).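

The direct swap gives a number 10.7 percentage points higher from compound 3 to compound 4 (beyond the scatter) in this assay, with the same atoms joined differently, so among these compounds the lower number goes with the 2-nitrophenyl group rather than with the presence of a nitro group alone. Two further steps, a number 3.9 percentage points lower from compound 2 to compound 4 (within the scatter) and a number 2.1 percentage points lower from compound 1 to compound 4 (within the scatter), show that neither nitro in place of methoxy on the aromatic carbon nor phenyl in place of methyl on the ring nitrogen separates these pairs. No measurement shown here explains why the two nitrophenyl groups differ.

As far as these compounds go, it remains open whether an amine or a carboxylic acid in place of the nitro group would keep the number as high as in compound 4. From the compounds shown here alone, it is also open whether the 2-nitrophenyl group would lower the number with methyl rather than phenyl on the ring nitrogen.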